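Swapping a tert-butylphenyl arm for a methoxyphenoxy arm

The source may hold more compounds than are shown below. What is called first, only, known or untested is meant among the compounds shown, and "the series" means these compounds.

Compound 2 `COc1cccc(CNCCCNc2ccnc3cc(-c4ccc(C(C)(C)C)cc4)ccc23)c1O` gives 32000 nM in a physicochemical assay for solubility, with a stated time of 18 h, at pH 7.4; on this read-out higher numbers stand for higher solubility and lower numbers for lower solubility. Its two measured neighbours sit at the same level: compound 1 `COc1ccc(-c2ccc3c(NCCCNCc4cccc(OC)c4O)ccnc3c2)cc1` gives 32000 nM in this assay, and compound 3 `CC(C)(C)c1ccc(-c2ccc3c(NCCCNCc4ccco4)ccnc3c2)cc1` gives 32000 nM. The two measured steps, no change at the digits printed from compound 1 to compound 2 (within the scatter) and no change at the digits printed from compound 2 to compound 3 (within the scatter), both stayed within the scatter, so compound 2 stands level with compound 1 and compound 3 with nothing to separate them.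

Compound 4 `COc1ccc(Oc2ccc3c(NCCCNCc4cccc(OC)c4O)ccnc3c2)cc1` differs from compound 2 by 4-methoxyphenoxy in place of 4-(tert-butyl)phenyl on an aromatic carbon. The step from compound 1 to compound 2 is the one that bears most directly on this change, as it also exchanged a group on that aromatic carbon, and it produced no shift. The step from compound 2 to compound 3 altered a different part of the molecule and likewise produced no shift. On this basis the step in this assay is expected to be no change at the digits printed from compound 2 to compound 4 (within the scatter), with no movement beyond the scatter. For compound 4 the estimate in this assay is 32000 nM, with a range from 16000 nM to 64000 nM.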

Compound 4, solubility: 14500 nM
The estimate for compound 4 lay 2.2-fold (0.34 log units) above the measured number, outside the stated range (below it).
By their numbers in this assay, from the lowest: compound 4; then compounds 1, 2 and 3 (each within the scatter of the next).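

The aromatic carbon that carries this arm is not indifferent in this assay: 4-methoxyphenoxy in place of 4-(tert-butyl)phenyl gives a 2.2-fold lower number from compound 2 to compound 4 (0.34 log units; beyond the scatter). The more telling comparison is 4-methoxyphenoxy in place of 4-methoxyphenyl, where the two groups differ by the oxygen linking the ring to the core, and it gives a 2.2-fold lower number from compound 1 to compound 4 (0.34 log units; beyond the scatter). The exchange between compound 1 and compound 2 stayed within the scatter, whereas compound 4 shows that a change at this carbon can pass beyond it, though only modestly.

Nothing available here accounts for the lower number. The compounds shown leave open whether an amine or a carboxylic acid on the outer ring, in place of the methoxy group, would move this read-out further.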